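A few compounds are considered here, and "the series" means these few. Any claim that something is new, unique, unknown or untested is made for them only; others in the source may bear on it.

Measured compounds in a functional assay on DU-145 cells (Homo sapiens) for inhibition, read by trypan blue exclusion, with a stated time of 96 h; on this read-out lower numbers stand for stronger inhibition of growth and higher numbers for weaker inhibition of growth:
compound 1 `CC(=O)Oc1ccc(/C=C(\C(=O)c2ccc(Cl)cc2)S(=O)(=O)c2ccc(C)cc2)cc1` with 25000 nM
compound 2 `COc1ccccc1/C=C(\C(=O)c1ccc(Cl)cc1)S(=O)(=O)c1ccc(C)cc1` with 1000 nM
compound 3 `O=C(/C(=C\c1ccc(O)c([N+](=O)[O-])c1)SCc1ccccc1Cl)c1ccc(Cl)cc1` with 10000 nM

Compound 3 stands second highest of the three numbers: its value lies between compound 1 at 25000 nM and compound 2 at 1000 nM. Compound 4 `Cc1ccc(S(=O)(=O)/C(=C/c2ccc(O)c([N+](=O)[O-])c2)C(=O)c2ccc(Cl)cc2)cc1` is not yet measured. It differs from compound 3 in one place: (4-methylphenyl)sulfonyl in place of (2-chlorobenzyl)sulfanyl on a double-bonded chain carbon bound to a carbonyl carbon and a double-bonded chain carbon. After this change, compound 4 carries the same (4-methylphenyl)sulfonyl as compounds 1 and 2.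

Going by the values given here, the only measured step, a 25-fold lower number from compound 1 to compound 2 (1.40 log units; beyond the scatter), changes a different position and does not bear on this exchange. Among the compounds with values here, no measured pair separates (2-chlorobenzyl)sulfanyl from (4-methylphenyl)sulfonyl, so the direction of the step in this assay cannot be read from the data. Because compound 1 carrying the entering group gives 25000 nM and compound 2 carrying the same group gives 1000 nM, the expected value of compound 4 is placed within that span, near compound 3. The expected step is therefore a 1.7-fold lower number from compound 3 to compound 4 (0.22 log units; within the scatter), which is no step beyond the scatter. Compound 4 is estimated at 6000 nM, with a range from 1000 nM to 30000 nM.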

Compound 4, concentration for 50% growth inhibition: 25000 nM
Estimate against measurement, compound 4: 4.2-fold (0.62 log units) below; measured number inside the range.
By their numbers in this assay, from the lowest: compound 2; then compound 3; then compounds 1 and 4 (each within the scatter of the next).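

In this assay, going by these compounds alone, the exchange of (2-chlorobenzyl)sulfanyl for (4-methylphenyl)sulfonyl, on a double-bonded chain carbon bound to a carbonyl carbon and a double-bonded chain carbon, gives a 2.5-fold higher number from compound 3 to compound 4 (0.40 log units; beyond the scatter) as the first direct reading at this position, with 4-hydroxy-3-nitrophenyl held fixed. With (4-methylphenyl)sulfonyl held fixed, 4-hydroxy-3-nitrophenyl in place of 4-acetoxyphenyl gives no change at the digits printed from compound 1 to compound 4 (within the scatter) and in place of 2-methoxyphenyl gives a 25-fold higher number from compound 2 to compound 4 (1.40 log units; beyond the scatter) on the same background. Nothing measured here explains why the numbers move at either place.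

The compounds shown leave open whether the sulfanyl-to-sulfonyl exchange reads the same way when 2-methoxyphenyl replaces 4-hydroxy-3-nitrophenyl. They also leave open how a carboxylic acid or an amine would read in place of the (4-methylphenyl)sulfonyl.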